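Urea Analogues Tested for Cytotoxicity on Raji Cells

The compounds below may be only part of what the source reports. "The series", "measured", "known", "first", "only" and "open" are said of these compounds alone.

Compound 1, `Cc1cc(NC(=O)Nc2ncccc2C)c2ccccc2n1`, gives > 25000 nM.
Compound 2, `Cc1cc(NC(=O)Nc2ccccc2C(N)=O)c2ccccc2n1`, gives > 25000 nM.
Compound 3, `COc1ccc(NC(=O)Nc2cc(C)nc3ccccc23)cc1OC`, gives > 25000 nM.

These three compounds were examined in an ADME assay on Raji cells (Homo sapiens) for cytotoxicity, with a stated time of 72 h; a higher number here means that more compound is needed for the effect, a lower number that less compound is needed. For compound 1 the reading is a limit of the measurement rather than a number. The same is true for compound 2. It is also true for compound 3. Among the measured compounds shown here, in other words, every compound measured so far sits at the limit of > 25000 nM in this assay, at which 3 of the 3 values shown sit, so no compound here stands apart from the others on this readout.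

Compound 4, `Cc1cc(NC(=O)Nc2cccc(F)c2)c2ccccc2n1`, is the next compound to be measured. It differs from compound 1 in one place: 3-fluorophenyl in place of 3-methylpyridin-2-yl on an amide-type nitrogen. For the measured compounds named here, because no two of the measured compounds differ from each other in just one place, there is no measured step that shows how such a change affects the reading. Going by the values given here, the only guide is that compound 1 itself gave a limit, so for compound 4 the expected change, a step that the limit leaves unreadable from compound 1 to compound 4, is none beyond the usual scatter, with the most likely outcome again a limit. The estimate for compound 4 is therefore 35000 nM, with a range from 12000 nM to 100000 nM.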

Compound 4, half-maximal effective concentration: > 25000 nM
Compound 4: only a limit was reported; the forecaster's own chance of this, stated with the estimate: 85%; the middle value lies beyond the limit too.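

Compound 1 and compound 4 both give only a limit, so no step can be read from one to the other: the limit of > 25000 nM in this assay, at which 4 of the 4 values shown sit.

The compounds shown leave open which change, if any, would give a real number rather than a limit in this assay on these cells.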